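The source may hold more compounds than are shown below. What is called first, only, known or untested is meant among the compounds shown, and "the series" means these compounds.

Of the compounds shown here, three sharing one core have been measured in a functional assay on HEK293 cells with D(4) dopamine receptor (Homo sapiens) as the target, read by FLIPR; on this read-out lower numbers stand for smaller maximal responses and higher numbers for larger maximal responses. Compound 1 `O/N=C(/CCN1CCN(c2ccccn2)CC1)c1ccccc1` gives 74%. Compound 2 `O/N=C(/CCN1CCN(c2ccccn2)CC1)c1ccccc1Cl` gives 64%; the change between the two, chloro in place of hydrogen on an aromatic carbon, produced a number 10 percentage points lower from compound 1 to compound 2 (within the scatter). Compound 3 `O/N=C(\CCN1CCN(c2ccccn2)CC1)c1cccc(F)c1` gives 72%, a number that sits within the scatter of both compound 1 and compound 2. Compound 4 `N#Cc1cccc(/C(CCN2CCN(c3ccccn3)CC2)=N/O)c1` has not yet been measured; it differs from compound 3 as cyano in place of fluoro on an aromatic carbon. Within the data shown here, the only measured step, also a swap on the aromatic ring, stayed within the scatter, so no step beyond the scatter is expected in this assay here either. Compound 4 is therefore estimated at 70%, with a range from 55% to 85%. The expected step is a number 2 percentage points lower from compound 3 to compound 4 (within the scatter).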

Compound 4, largest response reached (reported as efficacy), in percent of the reference or control that the assay uses: 48%
Beside the measured number, compound 4's estimate is 22 percentage points above it; the measured number lies below the stated range.
By their numbers in this assay, from the lowest: compound 4; then compounds 2, 3 and 1 (each within the scatter of the next).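

In this assay, cyano in place of fluoro on this aromatic carbon, meta to a large group, gives a number 24 percentage points lower from compound 3 to compound 4 (beyond the scatter). Unlike the chloro swap in the earlier step, this change goes beyond the scatter, so the group at this position can shift the maximal response on the shared core. Nothing available explains why this swap lowers the response. From the compounds shown here alone, whether the drop is specific to cyano remains open. A methoxy group or a carboxylic acid on the same carbon would show whether other groups there behave alike.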